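A few compounds are considered here, and "the series" means these few. Any claim that something is new, unique, unknown or untested is made for them only; others in the source may bear on it.

Measured in a functional assay on DU-145 cells (Homo sapiens) for inhibition, read by trypan blue exclusion, with a stated time of 96 h; a higher number here means a weaker inhibitor of growth, a lower number a stronger inhibitor of growth:

compound 1 `O=C(O)c1cc(/C=C(\C(=O)c2c(F)c(F)c(F)c(F)c2F)S(=O)(=O)c2ccc(Br)cc2)ccc1O`: > 100000 nM, a limit of the assay and not a number
compound 2 `O=C(/C(=C\c1ccc(Cl)c([N+](=O)[O-])c1)S(=O)(=O)c1ccc(Br)cc1)c1ccc(Br)cc1`: 10000 nM
compound 3 `O=C(O)c1cc(/C=C(/Sc2ccc(Br)cc2)C(=O)c2c(F)c(F)c(F)c(F)c2F)ccc1O`: 25000 nM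

The step of an at least 4.0-fold lower number from compound 1 to compound 3 (0.60 log units; beyond the scatter) is (4-bromophenyl)sulfanyl in place of (4-bromophenyl)sulfonyl on a double-bonded chain carbon bound to a carbonyl carbon and a double-bonded chain carbon. It is known only as a lower bound because compound 1 sits at the limit of > 100000 nM in this assay, at which 1 of the 3 values shown sits. Compound 2 differs from compound 1 in its core; that difference is not broken down here. Compound 4 `O=C(/C(=C\c1ccc(Cl)c([N+](=O)[O-])c1)Sc1ccc(Br)cc1)c1ccc(Br)cc1` is not yet measured; it differs from compound 2 by (4-bromophenyl)sulfanyl in place of (4-bromophenyl)sulfonyl on a double-bonded chain carbon bound to a carbonyl carbon and a double-bonded chain carbon, the same change as from compound 1 to compound 3, at the same place. On that one precedent, compound 4 is expected to give a lower number than compound 2 in this assay, with the step of a 4.0-fold lower number from compound 2 to compound 4 (0.60 log units; beyond the scatter) set against an at least 4.0-fold lower number from compound 1 to compound 3 (0.60 log units; beyond the scatter); the estimate for compound 4 is 2500 nM, between 800 nM and 10000 nM.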

Compound 4, concentration for 50% growth inhibition: 10000 nM
Estimate against measurement, compound 4: 4.0-fold (0.60 log units) below; the measured number falls inside the stated range.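

In this assay, (4-bromophenyl)sulfanyl in place of (4-bromophenyl)sulfonyl gives no change at the digits printed from compound 2 to compound 4 (within the scatter). The change therefore does not carry over at the same size from one core to the other: the same change on two cores in this assay, an at least 4.0-fold lower number (0.60 log units; beyond the scatter) from compound 1 to compound 3 and no change at the digits printed (within the scatter) from compound 2 to compound 4, at least 4.0-fold (0.60 log units) apart, beyond the scatter of two such steps Compound 1 stands at a limit of the assay and not at a number, so the earlier step is only a bound, and two cores neither give a rule for a third core nor show which part of a core sets the gap: the limit of > 100000 nM in this assay, at which 1 of the 4 values shown sits.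

Open, on these data alone, is how a (4-bromophenyl)sulfinyl group or an amine would behave on a double-bonded chain carbon bound to a carbonyl carbon and a double-bonded chain carbon. Also open, as far as these compounds go, is whether either would follow the step seen on one core, on the other, or neither.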